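The source may hold more compounds than are shown below. What is called first, only, known or untested is meant among the compounds shown, and "the series" means these compounds.

Measured compounds:
Compound 1, `COc1ccc2[nH]c(-c3ccc(Cl)cc3)c(Oc3ccc(Cl)cc3)c2c1`, in a functional assay on A549 cells (Homo sapiens) for inhibition, read by MTT assay, with a stated time of 72 h (a lower number here means a stronger inhibitor of growth, a higher number a weaker inhibitor of growth), compound 1 gives 59000 nM.
Compound 2, `CCOC(=O)C1CCN(C(=S)Sc2c(-c3ccc(Br)cc3)n(C)c3ccccc23)CC1`, in this assay compound 2 gives 72000 nM.

Both numbers sit high, so neither compound is a strong inhibitor of growth in this assay. Compound 1 has the lowest of the two numbers, but its nearest neighbour, compound 2, stands within the scatter of it, so the two cannot be told apart and no order can be read from them. Among the compounds with values here, no pair of measured compounds differs in just one place, so no single structural step has been measured here.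

Compound 3, `CCOC(=O)c1ccc2[nH]c(-c3ccc(Cl)cc3)c(Oc3ccc(Cl)cc3)c2c1`, has not been measured in this assay. It differs from compound 1 in one place: ethoxycarbonyl in place of methoxy on an aromatic carbon, on an aromatic carbon of a six-membered aromatic ring of carbon only, part of a fused system of two rings, meta to a fused ring and para to a fused ring. Within the data shown here, with no measured step of this kind to lean on, the expected step is a 1.2-fold lower number from compound 1 to compound 3 (0.07 log units; within the scatter), which is not beyond the scatter. Compound 3 is therefore estimated at 50000 nM, with a range from 15000 nM to 150000 nM.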

Compound 3, concentration for 50% growth inhibition: 28000 nM
For compound 3 the middle estimate is 1.8-fold (0.25 log units) above the measured one, and the stated range covers the measured number.
By their numbers in this assay, from the lowest: compound 3; then compounds 1 and 2 (each within the scatter of the next).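

In this assay, within the data shown here, the one change that can be read so far, ethoxycarbonyl in place of methoxy, gives a 2.1-fold lower number from compound 1 to compound 3 (0.32 log units; beyond the scatter). This shows that the group on this aromatic carbon, meta to a fused ring and para to a fused ring, can shift the number, and that the larger ethoxycarbonyl is tolerated here without any loss of growth inhibition, although the step is modest and compound 3 still sits high at 28000 nM. No measurement at hand speaks to the reason for this step.

The compounds shown leave open which part of the ethoxycarbonyl group goes with the lower number, the carbonyl or the ethyl end, and a carboxylic acid, a methyl ester or an amide at the same carbon would help to separate the two. They also leave open whether the trend carries on to a longer ester chain or holds for an amine at this place, since one step gives a single comparison and not a pattern.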